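From chloro to trifluoromethyl: compound 2 to compound 3

The source may report more compounds than this note shows. Statements on the series, on what has been measured and on what is new or still open speak of the compounds shown alone.

Of the compounds shown here, two have been read so far in a functional assay on KB cells (Homo sapiens) for inhibition, read by MTT assay, with a stated time of 24 h, tested at 1 ug/mL; a higher number here means more inhibition of growth at the concentration tested, a lower number less inhibition of growth. In this test compound 1 `O=C(CCCCC1CCSS1)Nc1cccc(C(F)(F)F)c1` gives 9.5%, a low reading. Compound 2 `O=C(CCCCC(S)CCS)Nc1cccc(Cl)c1` is reported as "not active" (no number reported), so compound 2 stands without a number and cannot be sized against compound 1.

Compound 3 `O=C(CCCCC(S)CCS)Nc1cccc(C(F)(F)F)c1` is still to be measured in this assay. For the measured compounds named here, the single structural change is trifluoromethyl in place of chloro on an aromatic carbon, meta to a large group. The rest of the structure stays the same.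

Going by the values given here, no measured pair isolates this exchange, so the data give no direct size for it. The expected step is none beyond the scatter, with growth inhibition staying low and no clear direction. Among the compounds with values here, the only readings available point that way, since compound 1 gives 9.5% and compound 2 gives "not active" (no number reported). A report of no activity would also fit this expectation. For compound 3 the expected inhibition is 8%, with an estimated range of 0% to 25%.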

Compound 3, percent growth inhibition at one concentration: "not active" (no number reported)
Compound 3: no number reported; the estimate stays without a comparison.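

In this assay, for the compounds shown here, compound 2 gives "not active" (no number reported) and compound 3 gives "not active" (no number reported), so no step from chloro to trifluoromethyl can be read. The compounds shown leave open whether this exchange alters growth inhibition at all, and by how much. No measurement shown bears on an explanation of this result.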